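Chloro for Fluoro: What Compound 4 Might Show

The compounds below may be only part of what the source reports. "The series", "measured", "known", "first", "only" and "open" are said of these compounds alone.

Compound 1 `O=C(Nc1ccccc1F)C(Cl)Cl` gives 87500 nM in a functional assay on A549 cells (Homo sapiens) for antiproliferative activity, read by MTT assay, with a stated time of 72 h; on this read-out lower numbers stand for stronger inhibition and higher numbers for weaker inhibition.
Compound 2 `O=C(Nc1ccccc1Cl)C(Cl)Cl` gives 50200 nM in this assay.
Compound 3 `O=C(Nc1ccc(F)cc1)C(Cl)Cl` gives 68400 nM in this assay.

Compound 1 and compound 3 are built from the same atoms joined differently; the difference between the two cores is not broken down here. From compound 1 to compound 2 the change is chloro in place of fluoro on an aromatic carbon, and it produced a 1.7-fold lower number from compound 1 to compound 2 (0.24 log units; within the scatter), a step that is within the usual scatter of repeated measurements.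

Compound 4 `O=C(Nc1ccc(Cl)cc1)C(Cl)Cl` has not yet been measured. It differs from compound 3 by chloro in place of fluoro on an aromatic carbon. This is the same kind of change as that from compound 1 to compound 2, but the place is not identical: in compound 2 the new chloro sits ortho to a group of 6 heavy atoms, whereas in compound 4 it sits para to a group of 6 heavy atoms.

In this assay the expected step is a 1.6-fold lower number from compound 3 to compound 4 (0.21 log units; within the scatter), resting on the small step seen from compound 1 to compound 2, a 1.7-fold lower number from compound 1 to compound 2 (0.24 log units; within the scatter), and on the value of compound 3, 68400 nM. Compound 4 is therefore estimated at 42000 nM, with a likely range from 20000 nM to 90000 nM.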

Compound 4, half-maximal inhibitory concentration: 20400 nM
Compound 4: the middle estimate sits 2.1-fold (0.31 log units) above what was measured, within the range that was stated.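

In this assay, putting chloro in place of fluoro on the aromatic carbon gave a 3.4-fold lower number from compound 3 to compound 4 (0.53 log units; beyond the scatter), a step large enough to stand clear of the usual variation between repeated measurements. The same change has now been seen on two cores, and the steps go the same way, with no real difference in size between them: the same change on two cores in this assay, a 1.7-fold lower number (0.24 log units; within the scatter) from compound 1 to compound 2 and a 3.4-fold lower number (0.53 log units; beyond the scatter) from compound 3 to compound 4, 1.9-fold (0.28 log units) apart, within the scatter of two such steps This supports carrying the change between these two cores, but the earlier step on its own lies within the scatter, so only the newer step is a clear change, and two cores cannot show that the result holds on any further core.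

The compounds shown carry only fluoro or chloro on the aromatic ring, which leaves open how a bromo, methoxy or trifluoromethyl group would behave in the same place. They also leave open what an amine or a carboxylic acid would do there, and why the chloro compounds give the numbers they do.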